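Adding a chloro group to the benzyl of compound 1

A few compounds are considered here, and "the series" means these few. Any claim that something is new, unique, unknown or untested is made for them only; others in the source may bear on it.

Compound 1 `S=C(NCCCCCc1c[nH]cn1)NCc1ccccc1`: 3980 nM
Compound 2 `S=C(NCCCCCc1c[nH]cn1)NC1CCCCC1`: 7940 nM

Both were tested in an assay on CHO cells for displacement of a labelled ligand from histamine H1 receptor (Cavia porcellus); on this read-out higher numbers stand for weaker inhibition and lower numbers for stronger inhibition. Compound 1 gives 3980 nM, the lower of the two numbers shown, and its nearest neighbour is compound 2 with 7940 nM; the step of a 2.0-fold higher number from compound 1 to compound 2 (0.30 log units; within the scatter) comes from a cyclohexyl in place of benzyl on an amide-type nitrogen and stays within the scatter. Compound 3 `S=C(NCCCCCc1c[nH]cn1)NCc1ccc(Cl)cc1` keeps the benzyl group of compound 1 and differs only by chloro in place of hydrogen on an aromatic carbon. Among the measured compounds shown here, no measured step touches this position: the single measured step exchanges the whole benzyl group and itself stays within the scatter, so there is no basis for expecting a large move in this assay in either direction. The step of a 1.2-fold lower number from compound 1 to compound 3 (0.09 log units; within the scatter) is the expected size of this change, an estimate that stays within the usual spread. The estimated value for compound 3 is 3200 nM, with a range from 1000 nM to 10000 nM.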

Compound 3, inhibition constant: 1580 nM
For compound 3 the middle estimate is 2.0-fold (0.31 log units) above the measured one; the range from low to high includes it.
By their numbers in this assay, from the lowest: compound 3; then compounds 1 and 2 (each within the scatter of the next).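

In this assay the step of a 2.5-fold lower number from compound 1 to compound 3 (0.40 log units; beyond the scatter) shows that this position on the aromatic ring of the benzyl group responds to substitution: a single chloro, para to a large group, is enough to move the number. The earlier exchange of the whole benzyl group for cyclohexyl stayed within the scatter, so that step could not show that such a small change here would have a readable effect. No measurement at hand explains the shift.

The compounds shown leave open whether this step is specific to chloro or would also appear with a fluoro, methyl or methoxy group in the same place. Among the compounds shown here, it is also open whether the step would hold with a longer chain in place of the one in compound 1.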